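Notes on the amide-to-carbamate exchange in the series

The source may report more compounds than this note shows. Statements on the series, on what has been measured and on what is new or still open speak of the compounds shown alone.

Measured so far:
compound 1 `Cc1cc(C(=O)Nc2cccc(F)c2)nn1Cc1cc(Cl)ccc1OCc1ccccc1` — in a physicochemical assay for lipophilicity, at pH 7.4 (on this read-out higher numbers stand for higher lipophilicity and lower numbers for lower lipophilicity), compound 1 gives 2.8
compound 2 `CC(=O)Nc1cc(C)n(Cc2cc(Cl)ccc2OCc2ccccc2)n1` — compound 2 gives > 3.7, a limit of the assay
compound 3 `Cc1cc(NC(=O)OC(C)(C)C)nn1Cc1cc(Cl)ccc1OCc1ccccc1` — compound 3 gives > 3.7, a limit of the assay

Compound 1 holds the only number shown; the other two values are limits, as noted in the limit of > 3.7 in this assay, at which 2 of the 3 values shown sit. Compound 4 `Cc1cc(NC(=O)OCc2ccccn2)nn1Cc1cc(Cl)ccc1OCc1ccccc1` is not yet measured and differs from compound 1 by (((pyridin-2-yl)methoxy)carbonyl)amino in place of (3-fluorophenyl)carbamoyl on an aromatic carbon. The closest measured step is a number at least 0.90 log units higher from compound 1 to compound 3 (beyond the scatter), where a (tert-butoxycarbonyl)amino group took the same place; a number at least 0.90 log units higher from compound 1 to compound 2 (beyond the scatter) points the same way. The step that the two limits leave unreadable from compound 2 to compound 3 gives no readable size for an exchange on the carbonyl carbon. A rise beyond the scatter is therefore expected for compound 4, a number 0.70 log units higher from compound 1 to compound 4 (beyond the scatter). Compound 4 is estimated at 3.5, between 3 and 4.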

Compound 4, distribution coefficient: 3.1
The estimate for compound 4 lay 0.40 log units above the measured number; the range from low to high includes it.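

In this assay, (((pyridin-2-yl)methoxy)carbonyl)amino in place of (3-fluorophenyl)carbamoyl gives a number 0.30 log units higher from compound 1 to compound 4 (within the scatter). Compound 4 stays clear of the limit that compound 2 and compound 3 reach. At the same position, the group on the carbamate oxygen changes the read-out: (pyridin-2-yl)methyl in place of tert-butyl gives a number at least 0.60 log units lower from compound 3 to compound 4 (beyond the scatter) in this series. On the carbonyl carbon, (pyridin-2-yl)methoxy in place of methyl gives a number at least 0.60 log units lower from compound 2 to compound 4 (beyond the scatter) and the full size of these two steps stays unread: the limit of > 3.7 in this assay, at which 2 of the 4 values shown sit.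

From the compounds shown here alone, how a benzyl group on that oxygen would compare with compound 4 remains open. So does the effect of an amine or a carboxylic acid at this position.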